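Replacing the (2-Aminophenyl)carbamoyl End with Hydroxycarbamoyl

The source may hold more compounds than are shown below. What is called first, only, known or untested is meant among the compounds shown, and "the series" means these compounds.

Measured so far:
compound 1, `CC(C)Oc1ccc(C(C)(C)O)cc1-c1cn(C)c(=O)c2[nH]c(C(=O)NCc3ccc(C(=O)NO)cc3)cc12`: 52 nM
compound 2, `Cn1cc(-c2ccccc2Oc2ccccc2)c2cc(C(=O)NCCCCC(=O)Nc3ccccc3N)[nH]c2c1=O`: limit only

In an assay on isolated protein for inhibition of protein deacetylase HDAC6 (Homo sapiens), read by fluorescence (a higher number here means a weaker inhibitor, a lower number a stronger inhibitor), compound 1 gives 52 nM. For compound 2 this assay reports only a limit, > 500 nM; compound 2 therefore sits at the limit of > 500 nM in this assay, at which 1 of the 2 values shown sits, the weaker end of what is shown. Compound 3, `Cn1cc(-c2ccccc2Oc2ccccc2)c2cc(C(=O)NCCCCCC(=O)NO)[nH]c2c1=O`, differs from compound 2 by (hydroxycarbamoyl)methyl in place of (2-aminophenyl)carbamoyl on a saturated chain carbon, four bonds along the chain from an amide-type nitrogen. Compound 3 is expected to come out clearly stronger than compound 2, a step well beyond the usual scatter, as compound 1, which also carries a hydroxycarbamoyl group, gives 52 nM. For compound 3 the estimate is 40 nM, with a likely range of 10 nM to 150 nM, a step of an at least 12-fold lower number from compound 2 to compound 3 (1.09 log units; beyond the scatter).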

Compound 3, half-maximal inhibitory concentration: 3.4 nM
For compound 3 the middle estimate is 12-fold (1.07 log units) above the measured one; measured number below the stated range.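

Swapping (2-aminophenyl)carbamoyl for (hydroxycarbamoyl)methyl on a saturated chain carbon, four bonds along the chain from an amide-type nitrogen, gives an at least 140-fold lower number from compound 2 to compound 3 (2.16 log units; beyond the scatter) in this assay. For the compounds shown here, this is the first direct evidence that the group at this position matters, since compound 1 and compound 2 differ in more than one place. Compound 2 is recorded only as a limit: the limit of > 500 nM in this assay, at which 1 of the 3 values shown sits.

Still open, from the compounds shown here alone, is whether losing the aromatic ring or gaining the hydroxycarbamoyl group counts more. Going by these compounds, how a carboxylic acid in that place, or a longer chain, would read also remains unknown.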